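Trading a Phenyl Ring for Ethoxy in a Shared Core

The compounds below may be only part of what the source reports. "The series", "measured", "known", "first", "only" and "open" are said of these compounds alone.

Of the compounds shown here, three built on one shared core have so far been tested in a functional assay on HepG2 cells (Homo sapiens) for inhibition, read by MTT assay, with a stated time of 72 h; on this read-out lower numbers stand for stronger inhibition and higher numbers for weaker inhibition. Compound 1 `Cc1ccc(-c2cc(C(=O)N3CCC4(CC3)CC(=O)c3nn(C(C)(C)C)cc3O4)c3ccccc3n2)cc1` gives 1440 nM. Compound 2 `CC(C)(C)n1cc2c(n1)C(=O)CC1(CCN(C(=O)c3cc(-c4ccc(F)cc4)nc4ccccc34)CC1)O2` gives 2930 nM. Compound 3 `CC(C)(C)n1cc2c(n1)C(=O)CC1(CCN(C(=O)c3cc(Cl)nc4ccccc34)CC1)O2` gives 4720 nM. Compound 2 therefore holds the second highest of the three numbers: its nearest neighbour is compound 3, reached by a 1.6-fold higher number from compound 2 to compound 3 (0.21 log units; within the scatter), while its furthest is compound 1, since the move a 2.0-fold higher number from compound 1 to compound 2 (0.31 log units; beyond the scatter) separates them.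

The next compound, compound 4 `CCOc1cc(C(=O)N2CCC3(CC2)CC(=O)c2nn(C(C)(C)C)cc2O3)c2ccccc2n1`, differs from compound 2 by ethoxy in place of 4-fluorophenyl on an aromatic carbon. Going by the values given here, two measured steps bear on this change, as each also removes an entire six-membered aromatic ring from the same carbon and puts a group with no ring in its place: a 3.3-fold higher number from compound 1 to compound 3 (0.52 log units; beyond the scatter) and a 1.6-fold higher number from compound 2 to compound 3 (0.21 log units; within the scatter). Both run toward higher numbers, one modestly and one within the scatter. Ethoxy, like chloro, enters with no ring, so the expected step in this assay is small and toward a higher number, a 1.5-fold higher number from compound 2 to compound 4 (0.19 log units; within the scatter). Compound 4 is accordingly estimated at 4500 nM, with a range from 1800 nM to 11000 nM.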

Compound 4, half-maximal inhibitory concentration: > 10000 nM
Compound 4: only a limit was reported; the forecaster's own chance of this, stated with the estimate: 5%; middle value at least 2.2-fold (0.34 log units) away from the limit.
By their numbers in this assay, from the lowest: compound 1; then compounds 2 and 3 (each within the scatter of the next). At a limit, above all of these: compound 4.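

In this assay compound 4 gives > 10000 nM, which is a limit and not a number, and it is the only such result in the set: the limit of > 10000 nM in this assay, at which 1 of the 4 values shown sits.

Even so, ethoxy on this aromatic carbon next to the ring nitrogen stands clearly apart from all three earlier groups, with an at least 3.4-fold higher number from compound 2 to compound 4 (0.53 log units; beyond the scatter), an at least 6.9-fold higher number from compound 1 to compound 4 (0.84 log units; beyond the scatter) and an at least 2.1-fold higher number from compound 3 to compound 4 (0.32 log units; beyond the scatter). The earlier compounds shown here left open whether removing the ring mattered much, since a 1.6-fold higher number from compound 2 to compound 3 (0.21 log units; within the scatter), but compound 3 and compound 4 both carry no ring at this carbon and still differ beyond the scatter, so the group that enters counts here and not only the ring that leaves.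

The compounds shown leave open how large these three steps really are, since each rests on a limit. They also leave open whether a methoxy group, a longer chain such as butoxy, or an amine such as dimethylamino on this carbon would fall with chloro or with ethoxy.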